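The source may hold more compounds than are shown below. What is called first, only, known or untested is meant among the compounds shown, and "the series" means these compounds.

Measured compounds:
- compound 1, `O=C(O)C[C@H](NC(=O)CCCCc1ccc2c(n1)NCCC2)c1cnc2ccccc2c1`: 5.8 mL/min/kg
- compound 2, `O=C(O)C[C@H](NC(=O)CCCCc1ccc2c(n1)NCCC2)c1cccc(F)c1`: 2 mL/min/kg
- compound 3, `O=C(O)C[C@H](NC(=O)CCCCc1ccc2c(n1)NCCC2)c1cncnc1`: 26 mL/min/kg

All three compounds share a core and differ only in the aromatic group on a saturated chain carbon bound to an amide-type nitrogen and a saturated chain carbon. In an in vivo ADME assay on the whole organism (plasma) for pharmacokinetics, with Canis familiaris (Canis lupus familiaris) as the target (on this read-out lower numbers stand for slow clearance and higher numbers for fast clearance), compound 1 sits second highest of the three, between compound 2 and compound 3. Replacing its quinolin-3-yl with 3-fluorophenyl gives a 2.9-fold lower number from compound 1 to compound 2 (0.46 log units; beyond the scatter), while replacing it with pyrimidin-5-yl gives a 4.5-fold higher number from compound 1 to compound 3 (0.65 log units; beyond the scatter), and between those two the gap is a 13-fold higher number from compound 2 to compound 3 (1.11 log units; beyond the scatter).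

Compound 4, `O=C(O)C[C@H](NC(=O)CCCCc1ccc2c(n1)NCCC2)c1ccc2nc(O)oc2c1`, has not yet been tested in this assay. It carries the change (2-hydroxy-1,3-benzoxazol-6-yl in place of quinolin-3-yl on a saturated chain carbon bound to an amide-type nitrogen and a saturated chain carbon). Neither measured step involves this group, so both bear only indirectly: swapping the aromatic group has moved the number in either direction by modest to large amounts. For compound 4 a step of a 1.6-fold higher number from compound 1 to compound 4 (0.19 log units; within the scatter) is expected, modest and upward. Compound 4 is therefore estimated at 9 mL/min/kg, within the range 3 mL/min/kg to 27 mL/min/kg.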

Compound 4, clearance in the Canis familiaris assay: 37 mL/min/kg
Estimate against measurement, compound 4: 4.1-fold (0.61 log units) below; the whole stated range lies below it.
By their numbers in the Canis familiaris assay, from the lowest: compound 2; then compound 1; then compounds 3 and 4 (each within the scatter of the next).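

In the Canis familiaris assay, 2-hydroxy-1,3-benzoxazol-6-yl gives a 6.4-fold higher number from compound 1 to compound 4 (0.80 log units; beyond the scatter) and a 19-fold higher number from compound 2 to compound 4 (1.27 log units; beyond the scatter), so heavy-atom count alone does not set the number at this position: this group and quinolin-3-yl hold equally many heavy atoms yet differ clearly. Against pyrimidin-5-yl the result is a 1.4-fold higher number from compound 3 to compound 4 (0.15 log units; within the scatter), so these two different groups cannot be told apart here. The same swap from quinolin-3-yl also changes a second measured property, as in a physicochemical assay for lipophilicity (a higher number here means a more lipophilic compound, a lower number a more polar compound), compound 1 gives 0.76 and compound 4 gives -0.24 here: the measured partition coefficient of compound 1, 0.76, and of compound 4, -0.24, a number 1.00 log units lower (beyond the scatter)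

This single pair cannot show whether lower lipophilicity itself raises clearance or merely accompanies it. Also open, on these data alone, is how a 2-methoxy-1,3-benzoxazol-6-yl group, which keeps both rings but replaces the hydroxy group, would behave at this position.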